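The source may report more compounds than this note shows. Statements on the series, on what has been measured and on what is new or still open speak of the compounds shown alone.

Compound 1 `Nc1nc(O)c2c(n1)n(C1OC(CO)[C@@H](O)[C@H]1O)c(=O)n2Cc1ccc(Cl)c(Cl)c1` gives 55% in a functional assay on the whole organism (B cells) with Mus musculus as the target; on this read-out lower numbers stand for smaller maximal responses and higher numbers for larger maximal responses.
Compound 2 `CCCCCCCCCCn1c(=O)n(C2OC(CO)[C@@H](O)[C@H]2O)c2nc(N)nc(O)c21` gives 0%.
Compound 3 `CCn1c(=O)n(C2OC(CO)[C@@H](O)[C@H]2O)c2nc(N)nc(O)c21` gives 82%.

Compound 3 stands highest of the three in this assay: a number 27 percentage points higher from compound 1 to compound 3 (beyond the scatter), a number 82 percentage points higher from compound 2 to compound 3 (beyond the scatter), and a number 55 percentage points lower from compound 1 to compound 2 (beyond the scatter). Compound 4 `NCC(O)Cn1c(=O)n(C2OC(CO)[C@@H](O)[C@H]2O)c2nc(N)nc(O)c21` differs from compound 3 in one place: 2-amino-1-hydroxyethyl in place of methyl on a saturated chain carbon bound to an aromatic nitrogen. Both measured steps at this position, from compound 2 and from compound 1 to compound 3, went upward as the group on the saturated chain carbon bound to the aromatic nitrogen became smaller; compound 4 grows again at that carbon, though less than either. A modest downward step is therefore expected, a number 14 percentage points lower from compound 3 to compound 4 (beyond the scatter), with no measured case of this kind of group to sharpen it. Compound 4 is estimated at 68%, between 40% and 92%.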

Compound 4, largest response reached (reported as maximal response), in percent of the reference or control that the assay uses: 110%
Estimate against measurement, compound 4: 42 percentage points below; the measured number lies above the stated range.
By their numbers in this assay, from the lowest: compound 2; then compound 1; then compound 3; then compound 4.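

In this assay the upward trend with smaller groups at this position fails: on the saturated chain carbon bound to an aromatic nitrogen, the larger 2-amino-1-hydroxyethyl in place of methyl gives a number 28 percentage points higher from compound 3 to compound 4 (beyond the scatter) and not a drop. The same group in place of 3,4-dichlorophenyl gives a number 55 percentage points higher from compound 1 to compound 4 (beyond the scatter) and in place of nonyl gives a number 110 percentage points higher from compound 2 to compound 4 (beyond the scatter) as the largest step in the series, which places compound 4 highest of the four. The data offer no measured explanation for this rise.

As far as these compounds go, whether the amine, the hydroxyl or both carry the gain remains open. A 2-aminoethyl or 2-hydroxyethyl chain at this carbon would separate the two, while a carboxylic acid there would test a different chain end.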